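Working notes: chloro to nitro on compound 2

This account rests on a few compounds, and the source may have more. Where it says the series, first, only, none or still open, it means among the compounds named here.

Measured so far in a functional assay on HL-60 cells (Homo sapiens) for inhibition, read by CCK-8 assay, with a stated time of 48 h; on this read-out lower numbers stand for stronger inhibition and higher numbers for weaker inhibition:
- compound 1 `COc1ccc(Oc2ccccc2-c2ccsc2S(=O)(=O)N2CCN(C(=S)Nc3ccc([N+](=O)[O-])cc3)CC2)cc1OC` gives > 50000 nM as a limit
- compound 2 `COc1ccc(Oc2ccc([N+](=O)[O-])cc2-c2ccsc2S(=O)(=O)N2CCN(C(=S)Nc3ccc(Cl)cc3)CC2)cc1OC` gives > 50000 nM as a limit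
- compound 3 `Cc1ccc(-c2ccsc2S(=O)(=O)NCCNC(=O)Nc2cc(C(F)(F)F)cc(C(F)(F)F)c2)c(Oc2ccc(O)c(O)c2)c1` gives 3700 nM as a number

Compound 2 stands at a limit, > 50000 nM, and has no number. Next comes compound 4 `COc1ccc(Oc2ccc([N+](=O)[O-])cc2-c2ccsc2S(=O)(=O)N2CCN(C(=S)Nc3ccc([N+](=O)[O-])cc3)CC2)cc1OC`, with nitro in place of chloro on an aromatic carbon as its difference from compound 2, nitro in place of chloro on an aromatic carbon, para to a large group. Among the compounds with values here, no one-place step between measured compounds sizes this change. Compound 1 already carries a 4-nitrophenyl group and stays at the limit > 50000 nM in this assay. No step beyond the usual scatter is therefore expected. The expected change is a number no higher from compound 2 to compound 4 (the limit leaves the size open), most likely with another limit reported. Compound 4 is estimated at 50000 nM, with an expected range of 15000 nM to 100000 nM.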

Compound 4, half-maximal inhibitory concentration: > 50000 nM
Compound 4: a limit, no number (the forecaster's own chance of this, stated with the estimate: 75%); the middle value sits exactly at the limit.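

No step can be read among compound 1, compound 2 and compound 4, whose values are all limits and not numbers: the limit of > 50000 nM in this assay, at which 3 of the 4 values shown sit. The compounds shown leave open whether nitro in place of chloro or hydrogen changes inhibition at all.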